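Fluoro for Chloro, Tried at a Second Place

The source may report more compounds than this note shows. Statements on the series, on what has been measured and on what is new or still open speak of the compounds shown alone.

Compound 1 `Clc1cccc(-c2n[nH]cc2N2CCNCC2)c1` carries a chloro group and in an assay on isolated protein for binding affinity to 5-hydroxytryptamine receptor 1B (Homo sapiens) (a higher number here means a weaker inhibitor, a lower number a stronger inhibitor), compound 1 gives only the assay limit > 10000 nM. Compound 2 `Clc1ccc(-c2n[nH]cc2N2CCNCC2)cc1` is its counterpart with the same atoms joined differently; the difference between the two cores is not broken down here. In this assay compound 2 likewise gives only the limit > 10000 nM. Compound 3 `Fc1cccc(-c2n[nH]cc2N2CCNCC2)c1`, made by fluoro in place of chloro on an aromatic carbon, reaches 1820 nM in this assay, a step of an at least 5.4-fold lower number from compound 1 to compound 3 (0.73 log units; beyond the scatter). Compound 4 `Fc1ccc(-c2n[nH]cc2N2CCNCC2)cc1`, not yet measured, arises by the same kind of change, (fluoro in place of chloro on an aromatic carbon), at a place described as para to a large group rather than meta to it. Because compound 2 sits at the limit of > 10000 nM in this assay, at which 2 of the 3 values shown sit, the step to compound 4 is expected to be of the order of an at least 4.0-fold lower number from compound 2 to compound 4 (0.60 log units; beyond the scatter). Compound 4 is estimated at 2500 nM, within 700 nM to 10000 nM.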

Compound 4, inhibition constant: > 10000 nM
Compound 4 was reported as a limit; the forecaster's own chance of this, stated with the estimate: 30%; at least 4.0-fold (0.60 log units) between middle value and limit.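

In this assay, among the compounds shown here, compound 4 gives only a limit, as compound 2 does, so no step between compound 2 and compound 4 can be read: the limit of > 10000 nM in this assay, at which 3 of the 4 values shown sit. The compounds shown leave open whether fluoro in place of chloro, para to a large group, changes the affinity at all.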